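The compounds below may be only part of what the source reports. "The series", "measured", "known", "first", "only" and "open" are said of these compounds alone.

Of the compounds shown here, two have been tested so far in a functional assay on MCF7 cells (Homo sapiens) for antiproliferative activity, read by MTT assay, with a stated time of 72 h; a higher number here means a weaker inhibitor, a lower number a stronger inhibitor. Compound 1, with the structure `CCOC(=O)c1cc(=O)c2cc(CSC(=S)N(C(C)C)C(C)C)ccc2o1`, carries a diisopropylamino group on its thiocarbonyl carbon. In this assay compound 1 gives > 25000 nM, which is a limit of the assay and not a measured number. Compound 2, `O=c1c(SC(=S)N2CCCC2)coc2ccc(Cl)cc12`, is the second tested compound. In this assay compound 2 gives > 25000 nM, again a limit rather than a number. For the measured compounds named here, compound 1 therefore stands where every value so far sits, namely at the limit of > 25000 nM in this assay, at which 2 of the 2 values shown sit, and there is no measured difference between the two compounds that could set a scale for how far a single change moves the read-out.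

The untested compound 3, `CCOC(=O)c1cc(=O)c2cc(CSC(=S)N(C)c3ccccc3)ccc2o1`, differs from compound 1 in one place: methyl(phenyl)amino in place of diisopropylamino on a thiocarbonyl carbon. Going by the values given here, with no measured step to lean on, the step from compound 1 to compound 3 is expected to be a step that the limit leaves unreadable from compound 1 to compound 3, that is small and most likely lost within the scatter. Compound 3 is estimated at 30000 nM, within a range from 8000 nM to 100000 nM, with a real chance that the result is again reported only as a limit.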

Compound 3, half-maximal inhibitory concentration: > 25000 nM
Compound 3: no number, only a limit; the forecaster's own chance of this, stated with the estimate: 70%; the middle value is on the limit's open side.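

In this assay compound 3 gives > 25000 nM, again a limit and not a number. Compound 1 also stands only at a limit, so no step between compound 1 and compound 3 can be read: the limit of > 25000 nM in this assay, at which 3 of the 3 values shown sit.

These compounds leave open how strongly any of them acts beyond that limit, and which change would give a measurable value.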